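Methoxy for Chloro on the Benzyl Ring of Compound 2

This account rests on a few compounds, and the source may have more. Where it says the series, first, only, none or still open, it means among the compounds named here.

Compound 1 `O=S(=O)(NCCCNCC1COc2ccccc2O1)c1cc(C(F)(F)F)cc(C(F)(F)F)c1` and compound 2 `O=S(=O)(NCCCNCc1cccc(Cl)c1)c1cc(C(F)(F)F)cc(C(F)(F)F)c1` share a core and differ only in the group on a saturated chain carbon bound to an amine nitrogen. In a functional assay on Capan-2 cells (Homo sapiens) for inhibition, read by MTT assay, with a stated time of 72 h (a higher number here means a weaker inhibitor of growth, a lower number a stronger inhibitor of growth), compound 1 gives 2500 nM. In this assay, among the compounds with values here, compound 2 gives 8000 nM, the highest of the two numbers, separated from its only neighbour by a 3.2-fold higher number from compound 1 to compound 2 (0.51 log units; beyond the scatter).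

Compound 3 `COc1cccc(CNCCCNS(=O)(=O)c2cc(C(F)(F)F)cc(C(F)(F)F)c2)c1` differs from compound 2 by one change: methoxy in place of chloro on an aromatic carbon. Within the data shown here, no measured step bears on this change; the single step available, a 3.2-fold higher number from compound 1 to compound 2 (0.51 log units; beyond the scatter), exchanges the whole ring system on the chain carbon and therefore says little about a substituent exchanged on an otherwise unchanged ring. The step of a 1.1-fold lower number from compound 2 to compound 3 (0.06 log units; within the scatter) expected in this assay is accordingly small, probably within the scatter, with no direction favoured. Compound 3 is estimated at 7000 nM, with a range from 2500 nM to 20000 nM.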

Compound 3, concentration for 50% growth inhibition: 6400 nM
Compound 3: middle estimate off by 1.1-fold (0.04 log units), on the high side; the range from low to high includes it.
By their numbers in this assay, from the lowest: compound 1; then compounds 3 and 2 (each within the scatter of the next).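

In this assay, methoxy in place of chloro on the aromatic carbon gives a 1.3-fold lower number from compound 2 to compound 3 (0.10 log units; within the scatter), so the two groups cannot be told apart at this place, even though methoxy, unlike chloro, is counted with a hydrogen-bond acceptor. The exchange of the ring system on the chain carbon now reads a 2.6-fold higher number from compound 1 to compound 3 (0.41 log units; beyond the scatter) and stays beyond the scatter, so the gap from compound 1 holds for both the 3-chlorophenyl and the 3-methoxyphenyl group. No measured finding accounts for either step.

The compounds shown leave open whether an amine or a carboxylic acid in place of chloro on this aromatic carbon would separate from compound 2 as compound 1 does. They also leave open whether a longer chain in the shared core would move compound 2 and compound 3 alike.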